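Replacing Bromine with Carbamoylmethyl on a Sulfonamide

The compounds below may be only part of what the source reports. "The series", "measured", "known", "first", "only" and "open" are said of these compounds alone.

Compound 1 `COc1ccccc1NC(=O)N[C@@H]1C2CCN(CC2)[C@@H]1Cc1cccnc1` in an assay on a protein complex for binding affinity to Neuronal acetylcholine receptor; alpha4/beta2 (Homo sapiens); on this read-out lower numbers stand for stronger inhibition and higher numbers for weaker inhibition: > 10000 nM, which is a limit of the assay and not a number.
Compound 2 `O=S(=O)(N[C@@H]1C2CCN(CC2)[C@@H]1Cc1cccnc1)c1ccc(Br)cc1` in this assay: > 10000 nM, again only a limit.

Neither measured compound yields a real number; both sit at the limit of > 10000 nM in this assay, at which 2 of the 2 values shown sit. Compound 2 therefore stands only at a limit, with no measured affinity to compare. Compound 3 `NC(=O)Cc1ccc(S(=O)(=O)N[C@@H]2C3CCN(CC3)[C@@H]2Cc2cccnc2)cc1` differs from compound 2 by carbamoylmethyl in place of bromo on an aromatic carbon. Within the data shown here, no step between measured compounds exists, so nothing shows how this change moves this assay. Compound 3 is expected to remain near the limit, and a step that the limit leaves unreadable from compound 2 to compound 3 is expected to be small. Compound 3 is estimated at 20000 nM, ranging from 6000 nM to 60000 nM.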

Compound 3, inhibition constant: > 10000 nM
Compound 3: a limit, no number; the forecaster's own chance of this, stated with the estimate: 80%; the middle value is on the limit's open side.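

Compound 2 and compound 3 both stop at a limit and not a number, so no step between them can be read: the limit of > 10000 nM in this assay, at which 3 of the 3 values shown sit.

What stays open is how strongly any of these compounds acts in this assay, and whether bromo or carbamoylmethyl makes any difference there.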